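Swapping the fused ring on compound 2: what to expect

The compounds below may be only part of what the source reports. "The series", "measured", "known", "first", "only" and "open" are said of these compounds alone.

Three compounds share the same lactone core carrying two benzyloxy groups and differ in the fused ring attached to the chain. Compound 1 `COc1nc(OC)c2c(ccn2C/C=C2\OC(=O)C(OCc3ccccc3)=C2OCc2ccccc2)n1` gives 47100 nM in a functional assay on SW-620 cells (Homo sapiens) for antiproliferative activity, read by MTT assay, with a stated time of 72 h; a lower number here means a stronger inhibitor, a higher number a weaker inhibitor. Compound 2 `O=C1O/C(=C\Cn2cnc3c(Cl)c(F)nc(F)c32)C(OCc2ccccc2)=C1OCc1ccccc1` gives 50000 nM in this assay, and compound 3 `COc1nc(OC)c2c(ccn2CCC2(O)NC(=O)C(OCc3ccccc3)=C2OCc2ccccc2)n1` gives 90700 nM. Compound 2 stands among these with both compound 1 and compound 3 within the usual scatter of it, so no ordering can be drawn from these numbers.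

Compound 4 `O=C1O/C(=C\Cn2cnc3ncc(Br)c-3c2)C(OCc2ccccc2)=C1OCc1ccccc1` is built from compound 2 by a group of 10 heavy atoms (6 carbon, 3 nitrogen, 1 bromine; one five-membered aromatic ring with 1 hetero atom, one six-membered aromatic ring with 2 hetero atoms) in place of a group of 12 heavy atoms (6 carbon, 3 nitrogen, 2 fluorine, 1 chlorine; one five-membered aromatic ring with 2 hetero atoms, one six-membered aromatic ring with 1 hetero atom), on a saturated chain carbon bound to a double-bonded chain carbon. Among the measured compounds shown here, no measured pair shows how such a change moves the value, and every number so far is weak. A step of a 1.3-fold lower number from compound 2 to compound 4 (0.10 log units; within the scatter) is expected, roughly none beyond the scatter. Compound 4 is estimated at 40000 nM, with a range from 12000 nM to 100000 nM.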

Compound 4, half-maximal inhibitory concentration: > 100000 nM
Compound 4: no number, only a limit; the forecaster's own chance of this, stated with the estimate: 25%; middle value at least 2.5-fold (0.39 log units) away from the limit.
By their numbers in this assay, from the lowest: compounds 1, 2 and 3 (each within the scatter of the next). At a limit, above all of these: compound 4.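

In this assay compound 4 gives no number, only a limit: the limit of > 100000 nM in this assay, at which 1 of the 4 values shown sits.

Putting the group of 10 heavy atoms in place of the group of 12 heavy atoms gives an at least 2.0-fold higher number from compound 2 to compound 4 (0.30 log units; that floor lies within the scatter), so this change at this position shows no sign of a stronger inhibitor, though that floor alone does not establish a real loss.

On these data alone, the change alters the ring hetero atoms and the halogens together, and the share of each remains unknown. Also open, as far as these compounds go, is whether an amine or a carboxylic acid on the saturated chain carbon, in place of the fused rings, would give a stronger inhibitor.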